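The compounds below may be only part of what the source reports. "The series", "measured", "known", "first", "only" and "open" are said of these compounds alone.

Measured so far:
Compound 1 `Nc1ccc(NC(=O)CCCCCCC(=O)NO)cc1`: 8500 nM
Compound 2 `O=C(CCCCCCC(=O)Nc1ccc(O)cc1)NO`: 11000 nM
Compound 3 `O=C(CCCCCCC(=O)Nc1ccc(Cl)cc1)NO`: 2300 nM

In a functional assay on SK-BR-3 cells (Homo sapiens) for antiproliferative activity, with a stated time of 48 h (a higher number here means that more compound is needed for the effect, a lower number that less compound is needed), compound 3 gives the lowest of the three numbers at 2300 nM and stands clear of both others. The measured steps to it are a 3.7-fold lower number from compound 1 to compound 3 (0.57 log units; beyond the scatter) for chloro in place of amino and a 4.8-fold lower number from compound 2 to compound 3 (0.68 log units; beyond the scatter) for chloro in place of hydroxy. Both are modest and beyond the scatter, whereas a 1.3-fold higher number from compound 1 to compound 2 (0.11 log units; within the scatter) stays within it.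

Compound 4 `N#Cc1ccc(NC(=O)CCCCCCC(=O)NO)cc1` has cyano in place of chloro on an aromatic carbon, para to a large group: cyano in place of chloro on an aromatic carbon. Among the compounds with values here, no measured step involves cyano, so these steps bear only indirectly and show the size of change seen so far at this place. A step no larger than those is expected in this assay and it may lean towards a higher number, since compound 3 at 2300 nM is the lowest so far. The estimated step is a 1.5-fold higher number from compound 3 to compound 4 (0.18 log units; within the scatter) and so stays within the scatter. For compound 4 the estimate is 3500 nM with an expected range from 1500 nM to 8000 nM in this measurement.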

Compound 4, half-maximal effective concentration: 8800 nM
Compound 4: middle estimate off by 2.5-fold (0.40 log units), on the low side, outside the stated range (above it).
By their numbers in this assay, from the lowest: compound 3; then compounds 1, 4 and 2 (each within the scatter of the next).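

In this assay cyano does not carry over what chloro gave at this place, with a 3.8-fold higher number from compound 3 to compound 4 (0.58 log units; beyond the scatter) as a modest step. Cyano instead falls in with the two other groups, with a 1.0-fold higher number from compound 1 to compound 4 (0.02 log units; within the scatter) and a 1.3-fold lower number from compound 2 to compound 4 (0.10 log units; within the scatter), so that amino, hydroxy and cyano cannot be told apart here and chloro alone stands clear among the four groups shown. No measurement at hand explains why chloro separates from the other three groups.

On these data alone, whether the lower number is particular to chloro stays open, and fluoro, bromo, methyl or trifluoromethyl at the same place on the shared core would bear on that. Also open, as far as these compounds go, is whether the gain from chloro persists with a shorter or longer chain in the core.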